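Pyridine nitrogen moved in compound 4 of a sigma series

The source may report more compounds than this note shows. Statements on the series, on what has been measured and on what is new or still open speak of the compounds shown alone.

Compound 3 `Cc1cccc2sc(NC(=O)CCN3CCN(c4ccccn4)CC3)nc12` gives 1000 nM in an assay on membranes from brain for displacement of a labelled ligand from Sigma non-opioid intracellular receptor 1 (Cavia porcellus), read by scintillation counting, with a stated time of 120 min (on this read-out higher numbers stand for weaker inhibition and lower numbers for stronger inhibition), the highest of the three numbers measured. Compound 1 `CCN1CCN(CCC(=O)Nc2nc3c(C)cccc3s2)CC1` gives 543 nM in this assay, and compound 2 `CCCCCCN1CCN(CCC(=O)Nc2nc3c(C)cccc3s2)CC1` gives 238 nM. The measured steps are a 1.8-fold higher number from compound 1 to compound 3 (0.27 log units; within the scatter), a 4.2-fold higher number from compound 2 to compound 3 (0.62 log units; beyond the scatter) and a 2.3-fold lower number from compound 1 to compound 2 (0.36 log units; beyond the scatter). Compound 4 `Cc1cccc2sc(NC(=O)CCN3CCN(c4ccncc4)CC3)nc12` differs from compound 3 by pyridin-4-yl in place of pyridin-2-yl on an amine nitrogen in a ring. For the measured compounds named here, no measured step moves the nitrogen within the aromatic ring; the two steps reaching compound 3 exchange a pyridin-2-yl for an ethyl or hexyl chain and carry no information about the position of the nitrogen. Accordingly no step beyond the scatter is expected, no change at the digits printed from compound 3 to compound 4 (within the scatter). Compound 4 is estimated at 1000 nM, within a range of 350 nM to 3000 nM.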

Compound 4, inhibition constant: 9600 nM
Estimate against measurement, compound 4: 9.6-fold (0.98 log units) below; measured number outside the range, above it.
By their numbers in this assay, from the lowest: compound 2; then compounds 1 and 3 (each within the scatter of the next); then compound 4.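

In this assay, the place of the ring nitrogen counts at this position: with the same atoms joined differently, pyridin-4-yl gives a clear loss against pyridin-2-yl (a 9.6-fold higher number from compound 3 to compound 4 (0.98 log units; beyond the scatter)). The earlier compounds shown here showed a pyridine only as pyridin-2-yl, which stayed within the scatter of ethyl. Pyridin-4-yl does not stay within the scatter of either chain (an 18-fold higher number from compound 1 to compound 4 (1.25 log units; beyond the scatter); a 40-fold higher number from compound 2 to compound 4 (1.61 log units; beyond the scatter)).

Going by these compounds, whether pyridin-3-yl or a plain phenyl ring would stand nearer compound 3 or compound 4 remains open. Nothing shown here gives a cause for the step from pyridin-2-yl to pyridin-4-yl.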